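Swapping the ring on the nitrogen of compound 1

The source may report more compounds than this note shows. Statements on the series, on what has been measured and on what is new or still open speak of the compounds shown alone.

Compound 1 `c1cc(NC2=NCCO2)cc(OC2CCCCC2)c1`: 12000 nM
Compound 2 `c1ccc(Oc2cccc(NC3=NCCO3)c2)cc1`: 9600 nM

In a functional assay on M21 cells (Homo sapiens) for inhibition, read by sulforhodamine B assay, with a stated time of 48 h (a lower number here means a stronger inhibitor of growth, a higher number a weaker inhibitor of growth), compound 1 gives 12000 nM, and compound 2 gives 9600 nM. For the measured compounds named here, these two values lie within the scatter of each other, so compound 1 stands level with the only other measured compound. Going by the values given here, the one measured step, a 1.3-fold lower number from compound 1 to compound 2 (0.10 log units; within the scatter), puts phenyl in place of cyclohexyl on an oxygen on an aromatic ring.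

Compound 3 `O=C(CCl)NC(=O)Nc1cccc(OC2CCCCC2)c1` keeps that cyclohexyl group and changes a different part of compound 1: a group of 7 heavy atoms (3 carbon, 1 nitrogen, 2 oxygen, 1 chlorine; no ring) in place of a group of 5 heavy atoms (3 carbon, 1 nitrogen, 1 oxygen; one five-membered non-aromatic ring with 2 hetero atoms), on a nitrogen on an aromatic ring. The ring leaves, and an open ((chloromethyl)carbonyl)carbamoyl group enters, on a nitrogen on an aromatic ring. Among the compounds with values here, no measured compound carries a change at this place, so the data offer no direct guide. Within the data shown here, the only indirect evidence is the small step seen with compound 2 at 9600 nM, made elsewhere in the molecule. A large move in this assay is therefore not expected, and neither direction is secure. The expected step is a 1.5-fold lower number from compound 1 to compound 3 (0.18 log units; within the scatter), which is no clear change beyond the scatter. The estimate for compound 3 is 8000 nM, with an expected range from 2000 nM to 30000 nM.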

Compound 3, concentration for 50% growth inhibition: 2700 nM
Compound 3: the middle estimate sits 3.0-fold (0.47 log units) above what was measured; low and high end bracket the measured number.
By their numbers in this assay, from the lowest: compound 3; then compounds 2 and 1 (each within the scatter of the next).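

For the compounds shown here, the place on a nitrogen on an aromatic ring now proves able to shift growth inhibition in this assay, which the earlier compounds could not show. Swapping the five-membered ring for the open ((chloromethyl)carbonyl)carbamoyl group gives a 4.4-fold lower number from compound 1 to compound 3 (0.65 log units; beyond the scatter) and lies beyond the scatter, whereas the only earlier change, on the oxygen, gave a 1.3-fold lower number from compound 1 to compound 2 (0.10 log units; within the scatter) and stayed within it. Nothing measured here explains why this open group makes the stronger inhibitor of growth, so the result records an effect without giving its cause.

The compounds shown leave open which part of the new group matters: an acetyl group in place of the (chloromethyl)carbonyl part would show whether the chlorine is needed, and a shorter urea ending in a plain amine would show whether the carbonyl-bearing chain is needed at all. They also leave open whether the same change on the nitrogen would have a similar effect with the phenyl group of compound 2 on the oxygen, in place of cyclohexyl.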